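Swapping the arylidene substituent in a thiazolidinone series

A few compounds are considered here, and "the series" means these few. Any claim that something is new, unique, unknown or untested is made for them only; others in the source may bear on it.

Compound 1 `Cc1ccc(-c2cc(/N=C3/NC(=O)CS3)cs2)cc1` shows how the shared core behaves in a functional assay on HCT-116 cells (Homo sapiens) for cytotoxicity, read by MTT assay, with a stated time of 72 h; a lower number here means a stronger inhibitor, a higher number a weaker inhibitor: in this assay compound 1 reports only a limit, > 50000 nM. Compound 2 `CN(C)c1ccc(/C=C2\S/C(=N\c3csc(-c4ccc(Cl)cc4)c3)NC2=O)cc1` carries a further arylidene arm on that core, and in this assay compound 2 gives 500 nM. Among the two values shown, compound 2 stands as the only numerical result; the other is a limit, which the record describes as the limit of > 50000 nM in this assay, at which 1 of the 2 values shown sits. Compound 3 `COc1ccc(/C=C2\S/C(=N\c3csc(-c4ccc(Cl)cc4)c3)NC2=O)cc1OC` differs from compound 2 in one place: 3,4-dimethoxyphenyl in place of 4-(dimethylamino)phenyl on a double-bonded chain carbon bound to a double-bonded ring carbon. For the measured compounds named here, no measured pair tracks this kind of change, so the size of its effect is unknown. Since the arylidene arm is what separates compound 2 from compound 1, compound 3 is expected to remain well clear of the limit, with a modest loss estimated from compound 2 to compound 3 of a 3.0-fold higher number from compound 2 to compound 3 (0.48 log units; beyond the scatter). For compound 3 the expected value is therefore 1500 nM, with a plausible range from 400 nM to 6000 nM.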

Compound 3, half-maximal inhibitory concentration: 1700 nM
For compound 3 the middle estimate is 1.1-fold (0.05 log units) below the measured one, within the range that was stated.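

In this assay, exchanging the aryl group on the arylidene arm gives a 3.4-fold higher number from compound 2 to compound 3 (0.53 log units; beyond the scatter), a modest step and the only one measured at this position. The position therefore responds to the group it carries, yet the dimethylamino group is not needed for a numerical result, since both arms give one. For the compounds shown here, compound 1, which has no arylidene arm, remains the only compound reported as a limit rather than a number: the limit of > 50000 nM in this assay, at which 1 of the 3 values shown sits.

This single step cannot separate the removal of the dimethylamino group from the arrival of the two methoxy groups. A plain phenyl, a 4-methoxyphenyl or a 4-(diethylamino)phenyl at this place would bear on that question, and why the value moves stays open.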